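From methyl to chloro on the lowest-reading compound

This account rests on a few compounds, and the source may have more. Where it says the series, first, only, none or still open, it means among the compounds named here.

In a functional assay on B16 cells (Mus musculus) for cytotoxicity, read by CCK-8 assay, with a stated time of 24 h (on this read-out higher numbers stand for weaker inhibition and lower numbers for stronger inhibition), compound 1 (`COc1ccccc1Oc1c(N)nc(-c2ccc(C)cc2)nc1Cl`) reads 17400 nM while compound 2 (`COc1ccccc1Oc1c(N)nc(-c2cccc(I)c2)nc1Cl`) reads 27600 nM and compound 3 (`COc1ccccc1Oc1c(N)nc(-c2ccc(C)cc2)nc1OCCO`) reads 8430 nM which is the lowest of the three numbers. Compound 4 (`COc1ccccc1Oc1c(N)nc(-c2ccc(Cl)cc2)nc1OCCO`) has not yet been measured. It differs from compound 3 by chloro in place of methyl on an aromatic carbon so that 4-methylphenyl becomes 4-chlorophenyl.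

For the measured compounds named here, no measured step makes this exact swap. The closest, 3-iodophenyl in place of 4-methylphenyl, changes the same group and gave a 1.6-fold higher number from compound 1 to compound 2 (0.20 log units; within the scatter) in this pair. The other step, 2-hydroxyethoxy in place of chloro, gave a 2.1-fold lower number from compound 1 to compound 3 (0.31 log units; beyond the scatter) but lies elsewhere on the molecule and says little here. Going by the first of these, the estimated change is a 1.0-fold higher number from compound 3 to compound 4 (0.00 log units; within the scatter) so no step beyond the scatter is expected in this assay and neither direction is favoured. Compound 4 is estimated at 8500 nM with an expected range from 4200 nM to 17000 nM in this measurement.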

Compound 4, half-maximal inhibitory concentration: 7740 nM
Compound 4: middle estimate off by 1.1-fold (0.04 log units), on the high side, and the stated range covers the measured number.
By their numbers in this assay, from the lowest: compounds 4 and 3 (each within the scatter of the next); then compounds 1 and 2 (each within the scatter of the next).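

In this assay the swap of 4-methylphenyl for 4-chlorophenyl gives a 1.1-fold lower number from compound 3 to compound 4 (0.04 log units; within the scatter), so at this place on the six-membered aromatic ring, para to a large group, chloro and methyl cannot be told apart in the presence of the 2-hydroxyethoxy group. The earlier step on this ring changed both the group and where it sat, whereas this one keeps the place fixed and exchanges only the group. No measurement here offers an explanation for how closely the two compounds agree.

Going by these compounds, a single exchange says little about this place as a whole, so it remains open whether an amine or a carboxylic acid there would read any differently from chloro and methyl. Also open, on these data alone, is whether the same swap would read alike with a longer chain, or with chloro, in place of the 2-hydroxyethoxy group.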